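Chloro for Fluoro, Tested Across Two Related Cores

This account rests on a few compounds, and the source may have more. Where it says the series, first, only, none or still open, it means among the compounds named here.

The measured compounds and their values:
- Compound 1, `Fc1ccccc1CSc1nnc(-c2cnccn2)o1`: in a functional assay on HeLa cells (Homo sapiens) for antiproliferative activity, read by MTT assay, with a stated time of 48 h (a higher number here means a weaker inhibitor, a lower number a stronger inhibitor), compound 1 gives 25300 nM.
- Compound 2, `Clc1ccccc1CSc1nnc(-c2cnccn2)o1`: in this assay compound 2 gives 23000 nM.
- Compound 3, `Fc1ccc(CSc2nnc(-c3cnccn3)s2)cc1`: in this assay compound 3 gives only a limit, > 50000 nM, not a number.

Compounds 1 and 2 differ in a single place: chloro in place of fluoro on an aromatic carbon. That change gave a 1.1-fold lower number from compound 1 to compound 2 (0.04 log units; within the scatter), so the two values cannot be told apart.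

Compound 4, `Clc1ccc(CSc2nnc(-c3cnccn3)s2)cc1`, has not yet been measured. It stands to compound 3 as compound 2 stands to compound 1, through (chloro in place of fluoro on an aromatic carbon). This is the same kind of change, not the same change: in compound 1 the fluoro sits ortho to a large group, while in compound 3 it sits para to a large group. The difference between the core of compound 1 and the core of compound 3 is not broken down here. Compound 3 sits at the limit of this assay, as the limit of > 50000 nM in this assay, at which 1 of the 3 values shown sits, notes.

The step from compound 3 to compound 4 is expected to be a step that the limit leaves unreadable from compound 3 to compound 4, because the same kind of change produced a 1.1-fold lower number from compound 1 to compound 2 (0.04 log units; within the scatter). Compound 4 is therefore estimated at 60000 nM in this assay, with a range of 25000 nM to 150000 nM, and most likely only a limit will be reported again.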

Compound 4, half-maximal inhibitory concentration: 18900 nM
The estimate for compound 4 lay 3.2-fold (0.50 log units) above the measured number; the measured number lies below the stated range.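

On the core of compound 3, chloro in place of fluoro gave an at least 2.6-fold lower number from compound 3 to compound 4 (0.42 log units; beyond the scatter), so on this core the chloro compound is the stronger of the pair in this assay, while on the core of compound 1 the two values could not be told apart. Compound 3 gives only a limit, > 50000 nM, which is a bound and not a number. In compound 4 the chloro sits para to a large group, unlike in compound 2, so the core and the place of the halogen change together, and this pair of steps does not show whether the effect of the change depends on the core: the same change on two cores in this assay, a 1.1-fold lower number (0.04 log units; within the scatter) from compound 1 to compound 2 and an at least 2.6-fold lower number (0.42 log units; beyond the scatter) from compound 3 to compound 4; the limit leaves it open whether they differ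

The compounds shown leave open how far the step from fluoro to chloro really reaches on the core of compound 3, and whether it would hold with the halogen elsewhere on the ring. They also leave open what other groups in that same place would do, such as a methoxy group, an amine or a carboxylic acid.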